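This account rests on a few compounds, and the source may have more. Where it says the series, first, only, none or still open, it means among the compounds named here.

In an ADME assay on the whole organism (plasma) for pharmacokinetics, with Rattus norvegicus as the target, with a stated time of 24 h, at a dose of 10 mg/kg by the oral route (on this read-out lower numbers stand for lower exposure and higher numbers for higher exposure at the dose given), three compounds have been measured. Compound 1 `C=CCNC(=O)C(=O)[C@H](CCCC)NC(=O)[C@@H]1[C@H]2[C@@H](CN1C(=O)[C@@H](NC(=O)NC1([C@H]3CCCS3(=O)=O)CCCCC1)C(C)(C)C)C2(C)C` gives 3180 ng.h/mL, compound 2 `CCC[C@H](NC(=O)[C@@H]1[C@H]2[C@@H](CN1C(=O)[C@@H](NC(=O)NC1([C@H]3CCCCS3(=O)=O)CCCCC1)C(C)(C)C)C2(C)C)C(=O)C(=O)NC1CC1` gives 138 ng.h/mL, and compound 3 `CC(C)(C)[C@H](NC(=O)NC1([C@H]2CCCCS2(=O)=O)CCCCC1)C(=O)N1C[C@@H]2[C@H]([C@H]1C(=O)N[C@@H](CCC1CC1)C(=O)C(=O)NC1CC1)C2(C)C` gives 574 ng.h/mL, the middle of the three numbers. Compound 4 `CC(C)(C)[C@H](NC(=O)NC1([C@H]2CCCS2(=O)=O)CCCCC1)C(=O)N1C[C@@H]2[C@H]([C@H]1C(=O)N[C@@H](CCC1CC1)C(=O)C(=O)NC1CC1)C2(C)C` departs from compound 3 in one place, on a saturated ring carbon of a six-membered non-aromatic ring of carbon only: 1,1-dioxothiolan-2-yl in place of 1,1-dioxothian-2-yl on a saturated ring carbon.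

Within the data shown here, no measured step isolates this exchange. Among the measured compounds shown here, the only step available, a 4.2-fold higher number from compound 2 to compound 3 (0.62 log units; beyond the scatter), is a modest one that concerns a saturated chain rather than this group, so it serves only as a guide to how far one change can move the numbers. For the measured compounds named here, compound 1 is the only measured compound that carries 1,1-dioxothiolan-2-yl, and its 3180 ng.h/mL stands higher than the number for compound 3, but the two also differ elsewhere. A rise beyond the scatter is therefore expected in this assay, with wide uncertainty. The expected change is a 2.6-fold higher number from compound 3 to compound 4 (0.42 log units; beyond the scatter). Compound 4 is estimated at 1500 ng.h/mL, with an expected range of 550 ng.h/mL to 4000 ng.h/mL.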

Compound 4, area under the concentration-time curve: 352 ng.h/mL
Compound 4: the middle estimate sits 4.3-fold (0.63 log units) above what was measured; measured number below the stated range.
By their numbers in this assay, from the lowest: compound 2; then compounds 4 and 3 (each within the scatter of the next); then compound 1.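

Among these compounds, compound 4 gives the first measured step that isolates this exchange: in this assay, replacing 1,1-dioxothian-2-yl with 1,1-dioxothiolan-2-yl on a saturated ring carbon of a six-membered non-aromatic ring of carbon only gives a 1.6-fold lower number from compound 3 to compound 4 (0.21 log units; within the scatter) and so does not separate the two compounds. At this position, with the rest of compound 3 kept, the ring size of the entering group therefore makes no difference that can be told from the usual scatter. No supporting measurement bears on this result.

On these data alone, it remains open whether the exchange would read the same with the other amide and side-chain groups seen in compound 1 and compound 2. Also open, as far as these compounds go, is how an open-chain methylsulfonyl group or a primary amine at this position would stand in this assay.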